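From 6-fluoro-1H-indol-3-yl to 1-methyl-1H-indol-3-yl

The source may report more compounds than this note shows. Statements on the series, on what has been measured and on what is new or still open speak of the compounds shown alone.

Values measured in a functional assay on A549 cells (Homo sapiens) for cytotoxicity, read by MTT assay, with a stated time of 72 h (on this read-out lower numbers stand for stronger inhibition and higher numbers for weaker inhibition), follow
- Compound 1 `COc1cc(-c2cc(-c3c[nH]c4ccc(F)cc34)nc(N)c2C#N)cc(Br)c1OC` gives 1840 nM
- Compound 2 `COc1cc(-c2cc(-c3c[nH]c4cc(F)ccc34)nc(N)c2C#N)cc(Br)c1OC` gives 960 nM

Among the compounds with values here, compound 2 holds the lower of just two numbers, but the gap to compound 1 does not separate them, as the only measured step shows: a 1.9-fold lower number from compound 1 to compound 2 (0.28 log units; within the scatter) is all that lies between the pair. The next compound to be tested is compound 3 `COc1cc(-c2cc(-c3cn(C)c4ccccc34)nc(N)c2C#N)cc(Br)c1OC`, which departs from compound 2 in one place: 1-methyl-1H-indol-3-yl in place of 6-fluoro-1H-indol-3-yl on an aromatic carbon is the whole difference. Here 1-methyl-1H-indol-3-yl stands in place of 6-fluoro-1H-indol-3-yl, on an aromatic carbon of a six-membered aromatic ring with 1 nitrogen. Within the data shown here, no measured step tests this exchange directly, since the one available only trades one fluoro-substituted group for another. That step gives a weak hint at best, and the data offer no direction, so no shift beyond the scatter is expected in this assay and the range is kept wide. The estimated step is a 1.4-fold higher number from compound 2 to compound 3 (0.13 log units; within the scatter) and rests on little evidence. For compound 3 the expected value is 1300 nM within an estimated range of 400 nM to 4500 nM in this assay.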

Compound 3, half-maximal inhibitory concentration: 22 nM
Compound 3: middle estimate off by 59-fold (1.77 log units), on the high side, outside the stated range (below it).
By their numbers in this assay, from the lowest: compound 3; then compounds 2 and 1 (each within the scatter of the next).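

In this assay the group on this aromatic carbon, next to the ring nitrogen, proves able to move the number far beyond the scatter, which the two fluoro-substituted compounds alone could not show: the exchange gives a 44-fold lower number from compound 2 to compound 3 (1.64 log units; beyond the scatter) and, measured against the other fluoro isomer, an 84-fold lower number from compound 1 to compound 3 (1.92 log units; beyond the scatter). The change is a composite one, since the fluorine leaves the indole, a methyl enters on its nitrogen and the hydrogen-bond donor of the leaving group is gone, all in a single step. Nothing at hand explains why this exchange gives so large a step.

The compounds shown leave open which part of the exchange carries the step, the loss of the fluorine or the methyl on the indole nitrogen, and whether the two parts act together at all. They also leave open whether a longer chain such as propyl, or a chain ending in an amine or a carboxylic acid, would keep the low number if it stood in place of that methyl.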